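The compounds below may be only part of what the source reports. "The series", "measured", "known", "first", "only" and "open" are said of these compounds alone.

Compound 1 `O=C(CN(c1nc(Cl)nc2[nH]cnc12)C1CC1)N[C@@H](CO)C(=O)OCc1ccccc1` is the reference point of this set. Among the compounds with values here, in a functional assay on the whole organism (Tail, strain ICR) with Mus musculus as the target, in the tail flick test, with a stated time of 150 min, at a dose of 25 umol/kg by the oral route (a higher number here means a stronger effect of the compound at the dose given, a lower number a weaker effect), compound 1 gives 27.9%, the largest of the three numbers recorded, although no other compound is separated from it beyond the scatter. Compound 2 `O=C(CN(c1nc(Cl)nc2[nH]cnc12)C1CC1)N[C@@H](CO)C(=O)O` gives 18.8% and compound 3 `NC(=O)C[C@H](NC(=O)CN(c1ncnc2c1ncn2C1CCCCO1)C1CC1)C(=O)OCc1ccccc1` gives 21.7%. Within the data shown here, the only step measured so far, a number 9.1 percentage points lower from compound 1 to compound 2 (within the scatter), concerns hydrogen in place of benzyl on an oxygen next to a carbonyl group and does not touch the side chain changed here.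

Compound 4 `NC(=O)C[C@H](NC(=O)CN(c1nc(Cl)nc2[nH]cnc12)C1CC1)C(=O)OCc1ccccc1` differs from compound 1 by carbamoyl in place of hydroxy on a saturated chain carbon, two bonds along the chain from an amide-type nitrogen and a carbonyl carbon. Among the measured compounds shown here, no measured step covers this exact change. The nearest comparison is compound 3, which already carries the carbamoylmethyl side chain together with the benzyl ester on a different core; its value 21.7% lies within the scatter of compound 1. On that basis no step beyond the scatter is expected in this assay for the change from compound 1 to compound 4, and the step of a number 3.9 percentage points lower from compound 1 to compound 4 (within the scatter) is an estimate only. Compound 4 is therefore expected to give about 24%, with a range of 12% to 36%.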

Compound 4, a percentage reported as activity, at one dose (the size of the read-out at that dose, not a potency): 13.5%
Beside the measured number, compound 4's estimate is 10.5 percentage points above it, within the range that was stated.
By their numbers in this assay, from the lowest: compounds 4, 2, 3 and 1 (each within the scatter of the next, the first and the last beyond it).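

In this assay, within the data shown here, replacing hydroxymethyl with carbamoylmethyl gives a number 14.4 percentage points lower from compound 1 to compound 4 (beyond the scatter), the first single change that lies beyond the scatter. Among these compounds, this side chain is therefore a place where the read-out responds to the group it carries, whereas the only earlier single-place step, a number 9.1 percentage points lower from compound 1 to compound 2 (within the scatter), concerns the benzyl ester and stays within the scatter. Nothing measured here bears on what lies behind the side-chain step.

The compounds shown leave open whether the lower read-out follows the carbamoyl group itself or the greater size of the side chain, a question that a carboxymethyl, an aminomethyl or a plain methyl group on the same saturated chain carbon, or a longer chain such as carbamoylethyl, would help to separate. Also open, from the compounds shown here alone, is whether the step carries over to the free carboxylic acid in place of the benzyl ester, and whether it reflects potency or time course, as the read-out comes from one dose at one stated time.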